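This account rests on a few compounds, and the source may have more. Where it says the series, first, only, none or still open, it means among the compounds named here.

Working notes on the series in a functional assay on OVCAR-5 cells (Homo sapiens) for inhibition, read by CCK-8 assay, with a stated time of 72 h, tested at 10 uM; on this read-out lower numbers stand for less inhibition of growth and higher numbers for more inhibition of growth at the one concentration tested. Compound 3 `CN(C)C(=O)c1cc2cnc(Nc3ccc(NC(=O)C4(C(=O)Nc5cccc(O)c5)CC4)cc3)nc2n1C1CCCC1` gives 86%, which lies within the scatter of both measured neighbours: compound 1 `CN(C)C(=O)c1cc2cnc(Nc3ccc(NC(=O)C4(C(=O)Nc5ccc(Cl)cc5)CC4)cc3)nc2n1C1CCCC1` gives 85.3% and compound 2 `CN(C)C(=O)c1cc2cnc(Nc3ccc(NC(=O)C4(C(=O)Nc5cccc(F)c5)CC4)cc3)nc2n1C1CCCC1` gives 85.6%. Compound 4 `CN(C)C(=O)c1cc2cnc(Nc3ccc(NC(=O)C4(C(=O)Nc5cccc(Cl)c5)CC4)cc3)nc2n1C1CCCC1` is the next analogue, with chloro in place of hydroxy on an aromatic carbon, meta to a large group: chloro in place of hydroxy on an aromatic carbon.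

Going by the values given here, no measured step makes this exact exchange. The closest is a number 0.4 percentage points higher from compound 2 to compound 3 (within the scatter), for hydroxy in place of fluoro on an aromatic carbon. Two further steps change the aryl group on the amide-type nitrogen: a number 0.3 percentage points higher from compound 1 to compound 2 (within the scatter), for 3-fluorophenyl in place of 4-chlorophenyl, and a number 0.7 percentage points higher from compound 1 to compound 3 (within the scatter), for 3-hydroxyphenyl in place of 4-chlorophenyl. All three stay within the scatter, so no step beyond the scatter is expected in this assay, in either direction. The estimated step is a number 1 percentage points lower from compound 3 to compound 4 (within the scatter). For compound 4 the expected value is 85%, with an estimated range of 78% to 91%.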

Compound 4, percent growth inhibition at one concentration: 88.1%
The estimate for compound 4 lay 3.1 percentage points below the measured number; the range from low to high includes it.
By their numbers in this assay, from the lowest: compounds 1, 2, 3 and 4 (each within the scatter of the next).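

In this assay, chloro in place of hydroxy gives a number 2.1 percentage points higher from compound 3 to compound 4 (within the scatter) and chloro in place of fluoro gives a number 2.5 percentage points higher from compound 2 to compound 4 (within the scatter), so this position, on an aromatic carbon meta to a large group, now carries three different substituents without a step beyond the scatter, even with the hydrogen-bond donor and acceptor counted for hydroxy gone. Going by these compounds alone, the first direct comparison of one substituent at two places, a number 2.8 percentage points higher from compound 1 to compound 4 (within the scatter) for 3-chlorophenyl in place of 4-chlorophenyl, also stays within the scatter, so this pair does not separate the two chloro placements. Nothing on hand accounts for these small steps. The compounds shown leave open whether an amine, a carboxylic acid or a longer chain such as ethoxy on this aromatic carbon would give a step beyond the scatter. They also leave open whether the four compounds would separate at concentrations other than the one tested.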